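The source may report more compounds than this note shows. Statements on the series, on what has been measured and on what is new or still open speak of the compounds shown alone.

Measured so far in a functional assay on HEK293 cells for agonist activity at probable G-protein coupled receptor 27 (Homo sapiens), read by a luciferase reporter and beta-arrestin recruitment, with a stated time of 10 min; a higher number here means that more compound is needed for the effect, a lower number that less compound is needed: compound 1 `Cc1cc(Cl)ccc1C(=O)Nc1ccc(S(=O)(=O)Nc2ccccc2)cc1` gives 912 nM; compound 2 `O=C(Nc1ccc(S(=O)(=O)Nc2ccccc2)cc1)c1ccc(Br)cc1F` gives 479 nM; compound 3 `O=C(Nc1ccc(S(=O)(=O)Nc2ccccc2)cc1)c1ccc(Cl)cc1F` gives 3980 nM.

Compound 3 has the highest number of the three, separated from both others by more than the scatter. Compound 4 `Cc1cc(Br)ccc1C(=O)Nc1ccc(S(=O)(=O)Nc2ccccc2)cc1` differs from compound 3 by 4-bromo-2-methylphenyl in place of 4-chloro-2-fluorophenyl on a carbonyl carbon. Going by the values given here, two measured steps bear on this change: a 4.4-fold higher number from compound 1 to compound 3 (0.64 log units; beyond the scatter) and an 8.3-fold higher number from compound 2 to compound 3 (0.92 log units; beyond the scatter). The move from compound 3 to compound 4 reverses both of those changes at once, so each points toward a lower number, and a step well beyond the scatter in that direction is expected. Compound 4 is therefore estimated at 300 nM, with a range of 80 nM to 1200 nM, corresponding to an expected step of a 13-fold lower number from compound 3 to compound 4 (1.12 log units; beyond the scatter).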

Compound 4, half-maximal effective concentration: 851 nM
Compound 4: middle estimate off by 2.8-fold (0.45 log units), on the low side; the measured number falls inside the stated range.
By their numbers in this assay, from the lowest: compounds 2, 4 and 1 (each within the scatter of the next); then compound 3.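

Methyl in place of fluoro gives a 1.8-fold higher number from compound 2 to compound 4 (0.25 log units; within the scatter), so the size of this change depends on which halogen is present: the same change on two cores in this assay, a 4.4-fold higher number (0.64 log units; beyond the scatter) from compound 1 to compound 3 and a 1.8-fold lower number (0.25 log units; within the scatter) from compound 4 to compound 2, 7.8-fold (0.89 log units) apart, beyond the scatter of two such steps Bromo in place of chloro gives a 1.1-fold lower number from compound 1 to compound 4 (0.03 log units; within the scatter), and its size likewise depends on the other group present: the same change on two cores in this assay, an 8.3-fold higher number (0.92 log units; beyond the scatter) from compound 2 to compound 3 and a 1.1-fold higher number (0.03 log units; within the scatter) from compound 4 to compound 1, 7.8-fold (0.89 log units) apart, beyond the scatter of two such steps The full replacement gives a 4.7-fold lower number from compound 3 to compound 4 (0.67 log units; beyond the scatter), so the two single changes do not add up, and among these compounds only compound 3 stands apart.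

The compounds shown leave open how a methoxy group or an amine in place of the halogen would read.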